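This account rests on a few compounds, and the source may have more. Where it says the series, first, only, none or still open, it means among the compounds named here.

Measured in an assay for inhibition of kynurenine 3-monooxygenase (Homo sapiens), read by mass spectrometry, with a stated time of 1 h; on this read-out higher numbers stand for weaker inhibition and lower numbers for stronger inhibition: compound 1 `O=C(O)CCn1c(=O)oc2cc(OCC3CCC3)c(Cl)cc21` gives 25.1 nM; compound 2 `O=C(O)CCn1c(=O)oc2cc(OCc3ccccc3)c(Cl)cc21` gives 25.1 nM; compound 3 `Cc1ccc([C@@H](C)Oc2cc3onc(CCC(=O)O)c3cc2Cl)nn1` gives 2 nM.

Compound 3 stands lowest of the three numbers, beyond the scatter from both compound 1 and compound 2, so it is the strongest inhibitor measured here. Compound 4 `C[C@@H](Oc1cc2onc(CCC(=O)O)c2cc1Cl)c1ccc(Cl)cn1` differs from it by 5-chloropyridin-2-yl in place of 6-methylpyridazin-3-yl on a saturated chain carbon bound to an oxygen on an aromatic ring and a saturated chain carbon. For the measured compounds named here, only one measured step touches this position: no change at the digits printed from compound 1 to compound 2 (within the scatter), and that step sat on a different core and exchanged a ring that is not aromatic for one that is. It suggests that swapping the ring on this chain carbon leaves this assay largely unchanged, though the present swap is not identical. For compound 4 a step of a 1.3-fold higher number from compound 3 to compound 4 (0.10 log units; within the scatter) is expected, within the scatter, giving an estimated 2.5 nM with a range of 0.8 nM to 8 nM.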

Compound 4, half-maximal inhibitory concentration in the kynurenine 3-monooxygenase assay: 3.16 nM
Beside the measured number, compound 4's estimate is 1.3-fold (0.10 log units) below it, and the stated range covers the measured number.
By their numbers in the kynurenine 3-monooxygenase assay, from the lowest: compounds 3 and 4 (each within the scatter of the next); then compounds 1 and 2 (each within the scatter of the next).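

In the kynurenine 3-monooxygenase assay, the exchange of two aromatic rings on the shared core gives a 1.6-fold higher number from compound 3 to compound 4 (0.20 log units; within the scatter), so this chain carbon keeps its low numbers with either 6-methylpyridazin-3-yl or 5-chloropyridin-2-yl. This extends the earlier hint, which came from a different core and a ring that was not aromatic. In a physicochemical assay for pharmacokinetics, at pH 6 (a higher number here means that the compound lasts longer, a lower number that the compound disappears faster), compound 3 gives > 1000 h as a limit of the assay. In the physicochemical assay compound 4 gives > 1000 h as a limit of the assay. Compounds 3 and 4 each give only a limit, so the step between them cannot be read: the limit of > 1000 h in the physicochemical assay, at which 2 of the 2 values shown sit.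

Going by these compounds, the ring and its substituent change together here, so their separate contributions stay open. Whether a pyridine ring carrying an amine would hold the number is also unknown.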